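Sulfonamide nitrogen substitution in a TRPV1 antagonist series

The source may report more compounds than this note shows. Statements on the series, on what has been measured and on what is new or still open speak of the compounds shown alone.

Compound 3 `CCN(c1ccc(C(C)C(=O)NCc2ccc(C(F)(F)F)nc2N2CCC(C)CC2)cc1F)S(C)(=O)=O` stands highest of the three measured numbers in an assay on cells for antagonist activity at transient receptor potential cation channel subfamily V member 1 (Homo sapiens), read by FLIPR and calcium flux, with a stated time of 15 min; a higher number here means a weaker inhibitor, a lower number a stronger inhibitor: compound 3 gives 22.7 nM, whereas compound 1 `CC1CCN(c2nc(C(F)(F)F)ccc2CNC(=O)C(C)c2ccc(NS(=O)(=O)C(C)C)c(F)c2)CC1` gives 8.7 nM and compound 2 `CC1CCN(c2nc(C(F)(F)F)ccc2CNC(=O)C(C)c2ccc(NS(N)(=O)=O)c(F)c2)CC1` gives 2.7 nM. Both steps into compound 3 are beyond the scatter: a 2.6-fold higher number from compound 1 to compound 3 (0.42 log units; beyond the scatter) and an 8.4-fold higher number from compound 2 to compound 3 (0.92 log units; beyond the scatter). Within the pair of unsubstituted sulfonamides the step of a 3.2-fold lower number from compound 1 to compound 2 (0.51 log units; beyond the scatter) is also beyond the scatter, so the sulfonamide end of the shared core is sensitive to change.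

Compound 4 `CC(=O)N(c1ccc(C(C)C(=O)NCc2ccc(C(F)(F)F)nc2N2CCC(C)CC2)cc1F)S(C)(=O)=O` differs from compound 3 in one place: acetyl in place of ethyl on a sulfonamide nitrogen. Among the measured compounds shown here, no measured step swaps one substituent for another on that nitrogen; the only step touching the nitrogen, a 2.6-fold higher number from compound 1 to compound 3 (0.42 log units; beyond the scatter), also alters the group on the sulfonyl sulfur, so it does not isolate the effect. The two compounds carrying a hydrogen on that nitrogen, compound 1 and compound 2, give the lower numbers, and compound 4 keeps the nitrogen substituted. Compound 4 is therefore expected to remain near compound 3, with a step in this assay of a 1.3-fold higher number from compound 3 to compound 4 (0.12 log units; within the scatter), and an estimated value of 30 nM within a range of 10 nM to 100 nM.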

Compound 4, inhibition constant: 11.9 nM
Beside the measured number, compound 4's estimate is 2.5-fold (0.40 log units) above it; the measured number falls inside the stated range.
By their numbers in this assay, from the lowest: compound 2; then compounds 1, 4 and 3 (each within the scatter of the next, the first and the last beyond it).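

Working notes on the sulfonamide nitrogen: in this assay, the swap of ethyl for acetyl is the first step that changes only the substituent on this nitrogen, and with (a 1.9-fold lower number from compound 3 to compound 4 (0.28 log units; within the scatter)) the two groups are not told apart. The earlier split between a hydrogen and a substituent on this nitrogen also loosens, since (a 1.4-fold higher number from compound 1 to compound 4 (0.14 log units; within the scatter)) stays within the scatter and only (a 4.4-fold higher number from compound 2 to compound 4 (0.64 log units; beyond the scatter)) lies beyond it, although both of these steps also alter the group on the sulfonyl sulfur. No supporting data bear on why ethyl and acetyl read alike here.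

The effect of a substituent on this nitrogen, set against a hydrogen, remains unisolated, as the shown compounds include no (methylsulfonyl)amino group carrying a hydrogen on the nitrogen to pair with compound 3 and compound 4. Also open, on these data alone, is whether the same tolerance extends to a longer chain such as butyl, or to a chain ending in an amine or a carboxylic acid, on this sulfonamide nitrogen.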